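Changing the Aryl Group on the Sulfonyl Sulfur of Compound 2

This account rests on a few compounds, and the source may have more. Where it says the series, first, only, none or still open, it means among the compounds named here.

Compound 2 `Cc1ccc2ncc(S(=O)(=O)c3ccc(Cl)c(Cl)c3)c(N3CCC(C)CC3)c2c1` stands lowest of the three numbers recorded in an assay on isolated protein for displacement of a labelled ligand from metabotropic glutamate receptor 5 (Homo sapiens), with a stated time of 60 min, tested at 1 uM (a lower number here means less inhibition, a higher number more inhibition at the concentration tested (going by the name of the read-out)), where compound 2 gives 82%. Its nearest neighbour is compound 1 `CC1CCN(c2c(S(=O)(=O)c3ccc(Cl)c(Cl)c3)cnc3ccc(Cl)cc23)CC1`, which in this assay gives 86%; the step of a number 4 percentage points lower from compound 1 to compound 2 (within the scatter) goes with methyl in place of chloro on an aromatic carbon. Furthest from compound 2 is compound 3 `CC1CCN(c2c(S(=O)(=O)c3ccc(Cl)c(Cl)c3)cnc3ccc(F)cc23)CC1`, which in this assay gives 91%; the steps of a number 5 percentage points higher from compound 1 to compound 3 (within the scatter) and a number 9 percentage points higher from compound 2 to compound 3 (within the scatter) go with fluoro in place of chloro and fluoro in place of methyl, each on an aromatic carbon. All three values lie close together, and none of the three steps reaches beyond the scatter.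

Compound 4 `Cc1ccc2ncc(S(=O)(=O)c3cc(F)cc(F)c3)c(N3CCC(C)CC3)c2c1` differs from compound 2 at another place: 3,5-difluorophenyl in place of 3,4-dichlorophenyl on a sulfonyl sulfur. Going by the values given here, none of the measured steps touches the group on the sulfonyl sulfur, so no measured step bears directly on this change, and the three steps that were measured only show that small changes elsewhere left the numbers in this assay nearly unchanged. Compound 4 is therefore estimated with wide uncertainty at 70%, between 40% and 92%. The expected step of a number 12 percentage points lower from compound 2 to compound 4 (beyond the scatter) is thus a modest decrease, but a result within the scatter of compound 2 would not surprise.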

Compound 4, a percentage reported as inhibition, at one concentration (the size of the read-out at that concentration, not a potency): 72%
Compound 4: the middle estimate sits 2 percentage points below what was measured; measured number inside the range.
By their numbers in this assay, from the lowest: compounds 4, 2, 1 and 3 (each within the scatter of the next, the first and the last beyond it).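

Going by these compounds alone, the step of a number 10 percentage points lower from compound 2 to compound 4 (within the scatter) is the first reading at the group on the sulfonyl sulfur, a position the earlier steps on the aromatic carbon of the core did not touch. In this assay, compound 4 gives 72% with 3,5-difluorophenyl on the sulfonyl sulfur, so this pair shows that the 3,4-dichlorophenyl group can be exchanged for an aryl group without chlorine while the step stays within the scatter, although the exchange alters both the halogen and the pattern of substitution on the ring. No measurement is available that accounts for the size of this step.

A single step with both of these alterations cannot show what either contributes alone, and it also leaves open whether the same exchange would read alike on the chloro and fluoro cores of compound 1 and compound 3. The compounds shown also leave open how this assay would respond to a larger departure on the sulfonyl sulfur, such as plain phenyl, a pyridine ring, a benzyl group or a cyclohexyl group.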